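Moving one fluorine on the benzyl group

The source may report more compounds than this note shows. Statements on the series, on what has been measured and on what is new or still open speak of the compounds shown alone.

Compound 1 `C[C@H](NC(=O)C(=O)NCc1ccc(Cl)cc1)C(=O)N[C@@H](CC(=O)O)C(=O)COc1c(F)c(F)cc(F)c1F`: 8.4 nM
Compound 2 `C[C@H](NC(=O)C(=O)NCc1cccc(F)c1)C(=O)N[C@@H](CC(=O)O)C(=O)COc1c(F)c(F)cc(F)c1F`: 106 nM

Among the measured compounds shown here, in a functional assay on Jurkat cells (Homo sapiens) (on this read-out lower numbers stand for stronger inhibition and higher numbers for weaker inhibition), compound 2, at 106 nM, has the higher of the two numbers so far, which makes it the weaker inhibitor of the pair. Compound 3 `C[C@H](NC(=O)C(=O)NCc1ccc(F)cc1)C(=O)N[C@@H](CC(=O)O)C(=O)COc1c(F)c(F)cc(F)c1F` has not yet been measured. It differs from compound 2 in a single place, with 4-fluorophenyl in place of 3-fluorophenyl on a saturated chain carbon bound to an amide-type nitrogen.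

For the measured compounds named here, only one measured step bears on this change: a 13-fold higher number from compound 1 to compound 2 (1.10 log units; beyond the scatter). It is a large step, but it replaced the halogen and moved it at the same time, so it cannot show how much of the loss comes from either change alone. Going by the values given here, no measured pair isolates the move of the fluorine. Even so, the 4-fluorophenyl of compound 3 most resembles the 4-chlorophenyl of compound 1, which gives 8.4 nM. Part of the large step is therefore expected to be recovered, and the expected change is a 3.8-fold lower number from compound 2 to compound 3 (0.58 log units; beyond the scatter). For compound 3 the estimated value is 28 nM, with an expected range from 9 nM to 90 nM.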

Compound 3, half-maximal inhibitory concentration: 197 nM
Estimate against measurement, compound 3: 7.0-fold (0.85 log units) below, outside the stated range (above it).
By their numbers in this assay, from the lowest: compound 1; then compounds 2 and 3 (each within the scatter of the next).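

In this assay, a 1.9-fold higher number from compound 2 to compound 3 (0.27 log units; within the scatter) shows that, for the fluorine, 3-fluorophenyl and 4-fluorophenyl on this saturated chain carbon bound to an amide-type nitrogen cannot be told apart. The earlier step from compound 1 to compound 2 swapped the halogen and shifted its place at once, whereas compound 1 and compound 3 differ only in fluoro in place of chloro on an aromatic carbon, and a 23-fold higher number from compound 1 to compound 3 (1.37 log units; beyond the scatter) is large and beyond the scatter, so the earlier drop now reads as tied to the identity of the halogen rather than to its place on the ring. Nothing given here explains why these two halogens separate so widely in this assay.

Going by these compounds, only fluoro is seen at both places on the ring, so whether the place would matter just as little for chloro stays open. On these data alone, it is equally open whether the low number of compound 1 is particular to chloro, or whether a bromo, a methyl group or a plain phenyl without any halogen would give a similar number on the same core.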